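Three Triazole-Fused Cores, All Beyond the Assay Limit

The source may hold more compounds than are shown below. What is called first, only, known or untested is meant among the compounds shown, and "the series" means these compounds.

Compound 1 `Cc1ncn2c(NCc3ccco3)nncc12`: > 48000 nM
Compound 2 `c1coc(CNc2nncc3cncn23)c1`: > 48000 nM
Compound 3 `CCCc1nc(C)c2c(C)nn(CC(=O)OCC)c(=O)n12`: > 48000 nM

In a functional assay for inhibition, with Homo sapiens as the target (a higher number here means a weaker inhibitor, a lower number a stronger inhibitor), compound 1 gives > 48000 nM, which is a limit of the assay rather than a number. Compound 2 likewise gives > 48000 nM in this assay, again a limit. The change from compound 1 to compound 2 is hydrogen in place of methyl on an aromatic carbon, and the step it made is a step that the two limits leave unreadable from compound 1 to compound 2. Compound 3 gives > 48000 nM in this assay, also a limit. The difference between the core of compound 1 and the core of compound 3 is not broken down here. Compound 4 `CCCc1nc(C)c2cnn(CC(=O)OCC)c(=O)n12` is not yet measured; it differs from compound 3 by hydrogen in place of methyl on an aromatic carbon, the same kind of change as that from compound 1 to compound 2, though here the place is a six-membered aromatic ring with 3 nitrogen, ortho to a fused ring, rather than a five-membered aromatic ring with 2 nitrogen. Because (the limit of > 48000 nM in this assay, at which 3 of the 3 values shown sit), compound 4 is expected to sit near that limit as well, with an expected step that the limit leaves unreadable from compound 3 to compound 4. The estimate for compound 4 in this assay is 70000 nM, expected to lie between 20000 nM and 250000 nM.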

Compound 4, half-maximal inhibitory concentration: > 48000 nM
Compound 4 was reported as a limit; the forecaster's own chance of this, stated with the estimate: 85%; the middle value does not contradict the limit.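

In this assay compound 4 gives > 48000 nM, which is a limit of the assay and not a number. Compound 3 is likewise reported only as a limit, and the step between compound 3 and compound 4 cannot be read. The compounds shown leave open what size of effect, if any, hydrogen in place of methyl has on inhibition in this assay.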